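This account rests on a few compounds, and the source may have more. Where it says the series, first, only, none or still open, it means among the compounds named here.

Compound 1 `N#CC1=C(N)Oc2c(c3nc4ccccc4nc3c3ccccc23)C12C(=O)N(Cc1cnnn1-c1ccc(N)cc1)c1ccccc12` and compound 2 `N#CC1=C(N)Oc2c(c3nc4ccccc4nc3c3ccccc23)C12C(=O)N(Cc1cnnn1-c1ccc(S(N)(=O)=O)cc1)c1ccccc12` share a core and differ by a sulfamoyl in place of amino on an aromatic carbon. In an ADME assay on L02 cells (Homo sapiens) for antiproliferative activity, read by MTT assay, with a stated time of 48 h (a lower number here means a stronger inhibitor, a higher number a weaker inhibitor), compound 1 gives > 50000 nM, which is a limit of the assay rather than a number. Compound 2 likewise gives > 50000 nM in this assay, again a limit. The step that the two limits leave unreadable from compound 1 to compound 2 therefore cannot be read in size, since the limit of > 50000 nM in this assay, at which 3 of the 3 values shown sit, holds both ends of it.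

Compound 3 `N#CC1=C(N)Oc2c(N)cc3nc4ccccc4nc3c2C12C(=O)N(Cc1cnnn1-c1ccccc1Cl)c1ccccc12` carries the amino group on the core itself and a 2-chlorophenyl on the triazole nitrogen. In this assay compound 3 gives > 50000 nM, which is also a limit and not a measured number. Compound 4 `N#CC1=C(N)Oc2c(N)cc3nc4ccccc4nc3c2C12C(=O)N(Cc1cnnn1-c1ccc(Cl)cc1[N+](=O)[O-])c1ccccc12` differs from compound 3 by 4-chloro-2-nitrophenyl in place of 2-chlorophenyl on an aromatic nitrogen.

Among the compounds with values here, no measured step bears directly on this change, and the one measured step, from compound 1 to compound 2, is itself unreadable because the limit of > 50000 nM in this assay, at which 3 of the 3 values shown sit, covers every value shown. On that basis the expected step that the limit leaves unreadable from compound 3 to compound 4 is none beyond the scatter, and compound 4 is estimated at 60000 nM, between 20000 nM and 200000 nM.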

Compound 4, half-maximal inhibitory concentration: > 50000 nM
Compound 4: a limit, no number; the forecaster's own chance of this, stated with the estimate: 85%; the middle value does not contradict the limit.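

Compound 3 and compound 4 both give only a limit, so the change from 2-chlorophenyl to 4-chloro-2-nitrophenyl cannot be read in size: the limit of > 50000 nM in this assay, at which 4 of the 4 values shown sit. The compounds shown leave open what number any of them would give in this assay and whether any of these changes alters it.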